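Exchanging the nitrogen substituent of compound 3

The compounds below may be only part of what the source reports. "The series", "measured", "known", "first", "only" and "open" are said of these compounds alone.

Among the compounds with values here, compound 3 `C=C(C)Cn1cc(/C=C/C(=O)CC(=O)C(=O)O)c2ccccc21` is the only compound with a number in an assay on isolated protein for inhibition of DNA nucleotidylexotransferase (Homo sapiens), read by scintillation counting, with a stated time of 10 min; on this read-out lower numbers stand for stronger inhibition and higher numbers for weaker inhibition: compound 3 gives 2.5 uM. Compound 1 `C=C(C)Cn1cc(/C=C/C(=O)CC(=O)C(=O)OCC)c2ccccc21` reaches only the limit of > 40 uM. Compound 2 `CCOC(=O)C(=O)CC(=O)/C=C/c1cn(-c2ccc(Cl)cc2)c2ccccc12` likewise stops at the limit of > 40 uM. Freeing the acid is read as an at least 16-fold lower number from compound 1 to compound 3 (1.20 log units; beyond the scatter). The exchange on the aromatic nitrogen is a step that the two limits leave unreadable from compound 1 to compound 2, because both ends sit at the limit of > 40 uM in this assay, at which 2 of the 3 values shown sit. Compound 4 `O=C(/C=C/c1cn(Cc2ccc(Cl)cc2)c2ccccc12)CC(=O)C(=O)O` differs from compound 3 by 4-chlorophenyl in place of 1-methylethenyl on a saturated chain carbon bound to an aromatic nitrogen. Within the data shown here, no measured step gives a readable size for such a change, so compound 4 is expected to move little, no change at the digits printed from compound 3 to compound 4 (within the scatter). Compound 4 is therefore estimated at 2.5 uM, between 0.8 uM and 8 uM.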

Compound 4, concentration for 50% inhibition: 10 uM
Compound 4: middle estimate off by 4.0-fold (0.60 log units), on the low side; measured number above the stated range.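

With the free acid in place, the group on the aromatic nitrogen gives a readable result in this assay: 2-methylprop-2-en-1-yl to 4-chlorobenzyl produces a 4.0-fold higher number from compound 3 to compound 4 (0.60 log units; beyond the scatter), a modest loss that leaves a measurable number. The ester pair could not show this, because both of its ends sit at a limit: the limit of > 40 uM in this assay, at which 2 of the 4 values shown sit. As far as these compounds go, whether the loss comes from the aromatic ring or from its chlorine stays open, as an unsubstituted benzyl group would be needed to separate them. From the compounds shown here alone, how a 4-methoxybenzyl group or a longer chain on this nitrogen would read also stays open.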